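Shrinking the Amine: Piperidine to Methylamino on the Shared Core

The source may report more compounds than this note shows. Statements on the series, on what has been measured and on what is new or still open speak of the compounds shown alone.

Measured compounds:
compound 1 `Cc1nc(-c2cnc(N3CCCC3)[nH]c2=O)ccc1Oc1ccnc(-c2cnn(C)c2)c1` — 56 nM
compound 2 `Cc1nc(-c2cnc(N3CCCCC3)[nH]c2=O)ccc1Oc1ccnc(-c2cnn(C)c2)c1` — 30 nM

In a functional assay on NFS-60 cells (Mus musculus) for antiproliferative activity, read by resazurin assay, with a stated time of 72 h (a lower number here means a stronger inhibitor, a higher number a weaker inhibitor), compound 1 gives 56 nM, while compound 2 gives 30 nM. Compound 2 has the lower of the two numbers, but the step of a 1.9-fold lower number from compound 1 to compound 2 (0.27 log units; within the scatter) lies within the scatter, so the two compounds cannot be separated on these data.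

Compound 3 `CNc1ncc(-c2ccc(Oc3ccnc(-c4cnn(C)c4)c3)c(C)n2)c(=O)[nH]1` differs from compound 2 in one place: methylamino in place of piperidin-1-yl on an aromatic carbon. Among the compounds with values here, the only measured step, from compound 1 to compound 2, exchanges one cyclic amine for another of different ring size and stays within the scatter. Within the data shown here, no measured step exchanges a cyclic amine for an open-chain methylamino, which also brings in a hydrogen-bond donor, so the available numbers bear on the change only loosely: they show that the size of the amine at this position has so far mattered little. The step of a 2.7-fold higher number from compound 2 to compound 3 (0.43 log units; beyond the scatter) is therefore expected to be modest, most likely toward a somewhat higher number, with wide uncertainty. Compound 3 is estimated to give 80 nM in this assay, with a range from 25 nM to 300 nM.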

Compound 3, half-maximal inhibitory concentration: 1300 nM
Beside the measured number, compound 3's estimate is 16-fold (1.21 log units) below it, and the stated range ends below it.
By their numbers in this assay, from the lowest: compounds 2 and 1 (each within the scatter of the next); then compound 3.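

Between the two ring amines the position had shown no separable difference, but it is clearly not indifferent to the group it carries: in this assay, going to methylamino gives a large rise from either ring amine (a 43-fold higher number from compound 2 to compound 3 (1.64 log units; beyond the scatter)) and (a 23-fold higher number from compound 1 to compound 3 (1.37 log units; beyond the scatter)). Both steps lie beyond the scatter, so the loss does not depend on which ring amine serves as the starting point, and what separates compound 3 from the other two is a far larger matter here than ring size alone. No independent measurement accompanies these numbers to account for the rise.

The change removes the ring, shrinks the group from piperidin-1-yl to methylamino and adds a hydrogen-bond donor all at once, and the compounds shown cannot tell these apart. Open, therefore, is where along this path the number climbs: dimethylamino would keep an open chain with no hydrogen on the attached nitrogen, azetidin-1-yl would keep a smaller ring, and ethylamino or a longer chain on the same nitrogen would test the size of the open-chain group.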